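The compounds below may be only part of what the source reports. "The series", "measured", "known", "first", "only" and "open" are said of these compounds alone.

In a functional assay on MCF7 cells (Homo sapiens) for antiproliferative activity, read by MTT assay, with a stated time of 72 h (on this read-out lower numbers stand for stronger inhibition and higher numbers for weaker inhibition), compound 1 (`Oc1ccccc1/C=N/NC(=S)N1CCOCC1`) gives > 64000 nM, which is a limit and not a number. Compound 2 (`C/C(=N\NC(=S)N1CCOCC1)c1ccccc1O`) gives 49200 nM. Compound 3 (`C/C(=N\NC(=S)Nc1ccccc1)c1cc(Cl)ccc1O`) gives 9990 nM, the lower of the two actual numbers, with the gap to compound 2 beyond the scatter. Compound 4 (`C/C(=N\NC(=S)N1CCOCC1)c1cc(Cl)ccc1O`) carries morpholin-4-yl in place of anilino on a thiocarbonyl carbon. Among the compounds with values here, no measured pair isolates this change. Within the data shown here, the only guide is compound 2, which also carries morpholin-4-yl and stands at 49200 nM. A rise beyond the scatter in this assay is therefore expected, meaning weaker inhibition, with the expected step of a 2.2-fold higher number from compound 3 to compound 4 (0.34 log units; beyond the scatter). Compound 4 is estimated at 22000 nM, with an expected range of 9000 nM to 55000 nM.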

Compound 4, half-maximal inhibitory concentration: 29200 nM
Compound 4: the middle estimate sits 1.3-fold (0.12 log units) below what was measured, within the range that was stated.
By their numbers in this assay, from the lowest: compound 3; then compounds 4 and 2 (each within the scatter of the next). At a limit, above all of these: compound 1.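

Morpholin-4-yl in place of anilino on a thiocarbonyl carbon can now be read directly in this assay and gives a 2.9-fold higher number from compound 3 to compound 4 (0.47 log units; beyond the scatter) on this single pair. Chloro in place of hydrogen on an aromatic carbon gives a 1.7-fold lower number from compound 2 to compound 4 (0.23 log units; within the scatter) and so shows no effect of chloro with morpholin-4-yl present. Nothing measured here accounts for either step. Open, on these data alone, is whether an open-chain amine such as dimethylamino on the thiocarbonyl carbon would stand nearer anilino or morpholin-4-yl. As far as these compounds go, what chloro does alongside anilino also stays open.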